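The source may hold more compounds than are shown below. What is called first, only, known or untested is meant among the compounds shown, and "the series" means these compounds.

Working notes on the series. Compound 1 `CC1CCCCN1C(=S)SCc1ccc(C(=O)Nc2ccccc2N)cc1` in a functional assay on HeLa cells (Homo sapiens) for antiproliferative activity, read by CCK-8 assay, with a stated time of 72 h, tested at 2 uM (on this read-out lower numbers stand for a weaker effect and higher numbers for a stronger effect at the one concentration tested), gives 45.5%, and compound 2 `CC1CCN(C(=S)SCc2ccc(C(=O)Nc3ccccc3N)cc2)CC1` gives 46.8%. Compound 3 `Nc1ccccc1NC(=O)c1ccc(CSC(=S)N2CCCc3ccccc32)cc1` gives 26.1%, the lowest of the three numbers. The steps of a number 19.4 percentage points lower from compound 1 to compound 3 (beyond the scatter) and a number 20.7 percentage points lower from compound 2 to compound 3 (beyond the scatter) both turn on the group carried by the thiocarbonyl carbon and run in the same direction, so that position is shown to move the read-out modestly. Compound 4 `CN(Cc1ccncc1)C(=S)SCc1ccc(C(=O)Nc2ccccc2N)cc1` changes the same position: methyl((pyridin-4-yl)methyl)amino in place of 1,2,3,4-tetrahydroquinolin-1-yl on a thiocarbonyl carbon. For the measured compounds named here, no measured step covers an acyclic amino group there, so the direction cannot be read off the measured steps. Compound 4 is expected to give 40% (range 25% to 55%), which means a step of a number 13.9 percentage points higher from compound 3 to compound 4 (beyond the scatter) is expected, with wide uncertainty.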

Compound 4, a percentage reported as inhibition, at one concentration (the size of the read-out at that concentration, not a potency): 29.5%
Estimate against measurement, compound 4: 10.5 percentage points above; low and high end bracket the measured number.
By their numbers in this assay, from the lowest: compounds 3 and 4 (each within the scatter of the next); then compounds 1 and 2 (each within the scatter of the next).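

With methyl((pyridin-4-yl)methyl)amino, the position now carries an acyclic amino group, and it does not separate from 1,2,3,4-tetrahydroquinolin-1-yl, showing a number 3.4 percentage points higher from compound 3 to compound 4 (within the scatter). Against the two methylpiperidinyl groups it shows a number 17.3 percentage points lower from compound 2 to compound 4 (beyond the scatter) and a number 16 percentage points lower from compound 1 to compound 4 (beyond the scatter), so among these four compounds the two groups holding an aromatic ring, in compound 3 and compound 4, fall together below the two without one. Nothing available explains this grouping. Open, as far as these compounds go, is whether an unsubstituted piperidin-1-yl, a morpholin-4-yl or a benzyl(methyl)amino group would fall with the methylpiperidinyl groups or with the aromatic pair.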